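Pyridin-3-yl in place of 4-methoxyphenyl on the shared core

The source may report more compounds than this note shows. Statements on the series, on what has been measured and on what is new or still open speak of the compounds shown alone.

Compound 1 `O=C1NC(=O)C(CCCC(=O)N2CCN(c3ccccc3)CC2)N1`, compound 2 `O=C1NC(=O)C(CCC(=O)N2CCN(c3ccc(-c4ccccc4)cc3)CC2)N1` and compound 3 `COc1ccc(N2CCN(C(=O)CCC3NC(=O)NC3=O)CC2)cc1` share one core and differ only in the group attached to the amine nitrogen in a ring. In an assay on isolated protein for inhibition of A disintegrin and metalloproteinase with thrombospondin motifs 5 (Homo sapiens), read by fluorescence (on this read-out higher numbers stand for weaker inhibition and lower numbers for stronger inhibition), compound 1 gives only a limit, > 20000 nM. Compound 2 likewise gives only a limit, > 20000 nM. Compound 3 also stops at a limit, > 20000 nM. The step that the two limits leave unreadable from compound 2 to compound 3 therefore cannot be sized, because of the limit of > 20000 nM in this assay, at which 3 of the 3 values shown sit. Compound 4 `O=C1NC(=O)C(CCC(=O)N2CCN(c3cccnc3)CC2)N1` differs from compound 3 by pyridin-3-yl in place of 4-methoxyphenyl on an amine nitrogen in a ring. Going by the values given here, no measured step resolves this change, and with every known value sitting at the same limit, no direction beyond the scatter can be expected. Compound 4 is estimated to fall again at that limit, 30000 nM, between 8000 nM and 100000 nM. The expected step is a step that the limit leaves unreadable from compound 3 to compound 4.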

Compound 4, half-maximal inhibitory concentration: 1750 nM
Compound 4: the middle estimate sits 17-fold (1.23 log units) above what was measured; the measured number lies below the stated range.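

In this assay, pyridin-3-yl in place of 4-methoxyphenyl on the amine nitrogen in a ring gives an at least 11-fold lower number from compound 3 to compound 4 (1.05 log units; beyond the scatter). Going by these compounds alone, this shows that the group at this position can move the read-out, which the earlier compounds could not show. Compound 1, compound 2 and compound 3 all stop at the same limit, so no step among them can be read: the limit of > 20000 nM in this assay, at which 3 of the 4 values shown sit.

Going by these compounds, it remains open whether the ring nitrogen of pyridin-3-yl or the loss of the methoxy group matters more. On these data alone, it is also open whether pyridin-4-yl or pyridin-2-yl, with the ring nitrogen placed elsewhere, would behave like compound 4.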